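The source may report more compounds than this note shows. Statements on the series, on what has been measured and on what is new or still open speak of the compounds shown alone.

In an ADME assay on L6 cells (Rattus norvegicus) for cytotoxicity, read by resazurin assay, with a stated time of 72 h (on this read-out higher numbers stand for weaker inhibition and lower numbers for stronger inhibition), compound 1 `Cc1ccccc1C(O)(c1ccc(Cl)cc1)c1cccnc1` reads 82000 nM while compound 2 `OC(c1ccc(Cl)cc1)(c1cccnc1)c1ccccc1Br` reads 55200 nM and compound 3 `OC(c1ccc(Cl)cc1)(c1cccnc1)c1cccc(Br)c1` reads 54100 nM on the same scale. Compound 3 stands within the scatter of both others: the steps are a 1.5-fold lower number from compound 1 to compound 3 (0.18 log units; within the scatter) and a 1.0-fold lower number from compound 2 to compound 3 (0.01 log units; within the scatter) with a 1.5-fold lower number from compound 1 to compound 2 (0.17 log units; within the scatter) also within the scatter. Compound 4 `NC(=O)c1cccc(C(O)(c2ccc(Cl)cc2)c2cccnc2)c1` differs from compound 3 by carbamoyl in place of bromo on an aromatic carbon with carbamoyl in place of bromo on an aromatic carbon. The measured steps cover only bromo for methyl and the 2-bromophenyl to 3-bromophenyl swap. None brings in carbamoyl, so they are a weak guide. The largest is a 1.5-fold lower number from compound 1 to compound 3 (0.18 log units; within the scatter) so no step beyond the scatter is expected in this assay here. The expected step is a 1.3-fold higher number from compound 3 to compound 4 (0.11 log units; within the scatter) and no more. Compound 4 is estimated at 70000 nM with an expected range of 30000 nM to 150000 nM for now.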

Compound 4, half-maximal inhibitory concentration: > 100000 nM
Compound 4: only a limit was reported; the forecaster's own chance of this, stated with the estimate: 20%; middle value at least 1.4-fold (0.15 log units) away from the limit.
By their numbers in this assay, from the lowest: compounds 3, 2 and 1 (each within the scatter of the next). At a limit, above all of these: compound 4.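

In this assay compound 4 is reported only as a limit, > 100000 nM. Carbamoyl in place of bromo, meta to a large group, gives an at least 1.8-fold higher number from compound 3 to compound 4 (0.26 log units; that floor lies within the scatter), so the floor of this step stays within the scatter and its true size cannot be read. This is the first change shown at this position that brings in a hydrogen-bond donor and acceptor, and compound 4 alone sits at the limit: the limit of > 100000 nM in this assay, at which 1 of the 4 values shown sits.

On these data alone, whether an amine or a carboxylic acid at this place would give a number inside the range remains open. Also open, as far as these compounds go, is how carbamoyl would read at the position of the bromo in compound 2.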